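Swapping the sulfur substituent on two amide cores

A few compounds are considered here, and "the series" means these few. Any claim that something is new, unique, unknown or untested is made for them only; others in the source may bear on it.

Three compounds have been measured in a functional assay on A549 cells (Homo sapiens) for inhibition, read by CCK-8 assay, with a stated time of 72 h, tested at 8 uM; on this read-out higher numbers stand for more inhibition of growth at the one concentration tested and lower numbers for less inhibition of growth:
compound 1 `Nc1ccccc1NC(=O)/C=C/c1ccc(CSc2ccc(F)cc2)cc1` gives 59.1%
compound 2 `Nc1ccccc1NC(=O)/C=C/c1ccc(CSCCc2ccccc2)cc1` gives 50.3%
compound 3 `Nc1ccccc1NC(=O)c1ccc(CSCCc2ccccc2)cc1` gives 84.1%

Compound 3 stands highest of the three, beyond the scatter from both compound 1 and compound 2. The difference between the core of compound 3 and the core of compound 2 is not broken down here. Compound 1 and compound 2 share a core, and their difference is 4-fluorophenyl in place of phenethyl on a sulfur; in this assay this gave a number 8.8 percentage points higher from compound 2 to compound 1 (within the scatter). The unmeasured compound 4 `Nc1ccccc1NC(=O)c1ccc(CSc2ccc(F)cc2)cc1` is derived from compound 3 by the same change, (4-fluorophenyl in place of phenethyl on a sulfur), at a place described in the same words. Because a number 8.8 percentage points higher from compound 2 to compound 1 (within the scatter) was within the scatter, the expected step is a number 1.9 percentage points higher from compound 3 to compound 4 (within the scatter). Compound 4 is therefore estimated at 86%, ranging from 72% to 96%.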

Compound 4, percent growth inhibition at one concentration: 44.5%
The estimate for compound 4 lay 41.5 percentage points above the measured number; measured number outside the range, below it.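

In this assay, 4-fluorophenyl in place of phenethyl on a sulfur gave a number 39.6 percentage points lower from compound 3 to compound 4 (beyond the scatter), so the result of this change on one core did not predict its result on the other: the same change on two cores in this assay, a number 8.8 percentage points higher (within the scatter) from compound 2 to compound 1 and a number 39.6 percentage points lower (beyond the scatter) from compound 3 to compound 4, 48.4 percentage points apart, beyond the scatter of two such steps

This shows that, within these two pairs, the outcome of the change depends on the core that carries it. It does not show why the two cores differ, or how the change would behave on any third core.

The compounds shown leave open how a plain phenyl or a benzyl on the sulfur would fare on either core. Such compounds would separate the part played by the fluorine from that played by the two-carbon chain of phenethyl.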